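Swapping the fluorophenoxy arm for a single chlorine

A few compounds are considered here, and "the series" means these few. Any claim that something is new, unique, unknown or untested is made for them only; others in the source may bear on it.

Compound 1 `Cc1nnsc1CO/N=C/c1c(C)nn(C)c1Oc1ccc(F)cc1` was tested in a functional assay on PANC-1 cells (Homo sapiens) for inhibition, read by MTT assay, with a stated time of 48 h (a lower number here means a stronger inhibitor, a higher number a weaker inhibitor), and gives > 50000 nM, which is a limit of the assay rather than a number. Compound 2 `Cc1nnsc1CO/N=C/c1c(C)nn(C)c1Oc1ccc(C(C)(C)C)cc1` in this assay gives > 50000 nM, again a limit. The change a step that the two limits leave unreadable from compound 1 to compound 2 therefore has no readable size, because both values sit at the limit of > 50000 nM in this assay, at which 2 of the 2 values shown sit. Compound 3 `Cc1nnsc1CO/N=C/c1c(C)nn(C)c1Cl` has not yet been measured in this assay; it differs from compound 1 by chloro in place of 4-fluorophenoxy on an aromatic carbon. Within the data shown here, the only measured step concerns a different part of the molecule and gives no readable size, so no direction can be expected beyond the usual scatter, and a value at the limit again is the likeliest outcome. Compound 3 is therefore estimated at 50000 nM, within a range from 10000 nM to 200000 nM, which means an expected step of a number no higher from compound 1 to compound 3 (the limit leaves the size open) of essentially no size.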

Compound 3, half-maximal inhibitory concentration: 26600 nM
Compound 3: the middle estimate sits 1.9-fold (0.27 log units) above what was measured; the measured number falls inside the stated range.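

Among these compounds, at this aromatic carbon, the change from 4-fluorophenoxy to chloro gives the first step with any readable size, in this assay: an at least 1.8-fold lower number from compound 1 to compound 3 (0.27 log units; that floor lies within the scatter). Compound 3 therefore shows that a number within the range of this assay does not require the 4-fluorophenoxy arm and its six-membered aromatic ring, as a single chloro on the shared core is enough. The true size of the step stays unknown and may not exceed the scatter, and the other compounds give only a limit: the limit of > 50000 nM in this assay, at which 2 of the 3 values shown sit.

The compounds shown leave open whether chloro itself matters or whether removing the large arm is enough, which an amine or a methoxy group at this position could help to separate. They also leave open whether a longer chain there would keep a readable number.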